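Hydantoin in place of the alkylidene oxazolidinedione at the chain carbon

This account rests on a few compounds, and the source may have more. Where it says the series, first, only, none or still open, it means among the compounds named here.

Measured compounds and values:
- compound 1 `C/C(=C1/OC(=O)NC1=O)C(c1ccc(-c2ccc3cccc(F)c3c2)[nH]c1=O)C(C)C`: 17 nM
- compound 2 `CCC(/C=C1\OC(=O)NC1=O)(CC)c1ccc(-c2ccc3cc(F)cc(F)c3c2)[nH]c1=O`: 28 nM
- compound 3 `CC(C)(/C=C1\OC(=O)NC1=O)c1ccc(-c2ccc3cccc(F)c3c2)[nH]c1=O`: 38 nM

The series is read in an assay on membranes from Chem-1 cells for displacement of a labelled ligand from prostaglandin E2 receptor EP3 subtype (Homo sapiens), read by scintillation counting, with a stated time of 2 h; a lower number here means a stronger inhibitor, a higher number a weaker inhibitor. Compound 1 gives the lowest number of the three; its gap to compound 2 lies within the scatter of repeated runs, so the two cannot be ranked against each other, whereas its gap to compound 3 lies beyond the scatter. For the measured compounds named here, compound 3 carries a gem-dimethyl chain carbon, compound 2 a diethyl chain carbon and a second fluorine on the bicyclic ring; neither pair with compound 1 differs in one place only, so no single step is drawn among them.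

Compound 4 `CC(C)C(c1ccc(-c2ccc3cccc(F)c3c2)[nH]c1=O)C1NC(=O)NC1=O` has not yet been run in this assay. Against compound 1 the change is a group of 7 heavy atoms (3 carbon, 2 nitrogen, 2 oxygen; one five-membered non-aromatic ring with 2 hetero atoms) in place of a group of 9 heavy atoms (5 carbon, 1 nitrogen, 3 oxygen; one five-membered non-aromatic ring with 2 hetero atoms), on a saturated chain carbon bound to an aromatic carbon and a saturated chain carbon. The exocyclic double bond that linked the ring to the chain in compound 1 is gone, and the ring now carries two hydrogen-bond donors rather than one. Going by the values given here, no measured pair shows this change, so its effect is not known from the data. A modest weakening is expected, a 3.5-fold higher number from compound 1 to compound 4 (0.55 log units; beyond the scatter), since compound 1 at 17 nM is the reference. Compound 4 is therefore estimated at 60 nM, with a range from 20 nM to 200 nM.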

Compound 4, inhibition constant: 50 nM
Compound 4: middle estimate off by 1.2-fold (0.08 log units), on the high side; measured number inside the range.
By their numbers in this assay, from the lowest: compounds 1, 2, 3 and 4 (each within the scatter of the next, the first and the last beyond it).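

In this assay, for the compounds shown here, the first single-place step gives a 2.9-fold higher number from compound 1 to compound 4 (0.47 log units; beyond the scatter), so at this saturated chain carbon the alkylidene oxazolidinedione can give way to 2,5-dioxoimidazolidin-4-yl at a modest cost. The exocyclic double bond of compound 1 is thus not needed for measurable binding, as compound 4 without it still gives 50 nM. No measurement on hand accounts for the size of this step.

As far as these compounds go, this one step does not separate the change of ring from the loss of the double bond, and the effect of 2,5-dioxoimidazolidin-4-yl alongside the gem-dimethyl chain carbon of compound 3 or the diethyl chain carbon of compound 2 remains open. Also open, from the compounds shown here alone, is whether a carboxylic acid or a primary amide at this chain carbon could take the place of a ring.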